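This account rests on a few compounds, and the source may have more. Where it says the series, first, only, none or still open, it means among the compounds named here.

The two measured compounds, compound 1 `CSc1cc(N)nc2[nH]cnc12` and compound 2 `CSc1cc(N)nc2c1ncn2[C@@H]1O[C@H](CO)[C@@H](O)[C@H]1O`, were both tested in a functional assay on HEp-2 cells (Homo sapiens) for cytotoxicity; on this read-out higher numbers stand for an effect only at larger amounts of compound and lower numbers for an effect already at smaller amounts. In this assay compound 1 gives > 22 ug/mL, which is a limit of the assay and not a number. Compound 2 likewise gives only a limit in this assay, namely > 22 ug/mL. Both results sit at the limit of > 22 ug/mL in this assay, at which 2 of the 2 values shown sit, so neither compound shows a measurable effect within the tested range, and compound 2 stands at that edge together with compound 1 rather than at any defined point. Within the data shown here, no step between two measured compounds can be drawn from this.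

Compound 3 `Nc1cc(S)c2ncn([C@@H]3O[C@H](CO)[C@@H](O)[C@H]3O)c2n1` differs from compound 2 in one place: hydrogen in place of methyl on a sulfur. With both known values at a limit, the step is expected to be a step that the limit leaves unreadable from compound 2 to compound 3, none beyond the usual scatter, in either direction. Compound 3 is therefore estimated at 30 ug/mL, in a range from 15 ug/mL to 100 ug/mL, with a good chance that this assay again reports only a limit.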

Compound 3, concentration for half-maximal effect: > 22 ug/mL
Compound 3: only a limit was reported; the forecaster's own chance of this, stated with the estimate: 75%; the middle value does not contradict the limit.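

In this assay compound 3 gives > 22 ug/mL, which is a limit of the assay and not a number. No step from compound 2 to compound 3 can be read, because both stand at the same edge: the limit of > 22 ug/mL in this assay, at which 3 of the 3 values shown sit.

The compounds shown leave open at what amount, if any, each would produce an effect in this assay, and so whether hydrogen in place of methyl on a sulfur matters.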